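This account rests on a few compounds, and the source may have more. Where it says the series, first, only, none or still open, it means among the compounds named here.

In an assay on isolated protein for inhibition of thyroid hormone receptor beta (Homo sapiens), read by fluorescence, with a stated time of 30 min (a higher number here means a weaker inhibitor, a lower number a stronger inhibitor), compound 3 `COc1cc(C(=O)N2CC(C)OCC2CCO)cc2nc(NCc3cc(Cl)ccn3)oc12` gives 29 nM, the second highest of three numbers. Compound 1 `COc1cc(C(=O)N2CCC(O)C(C)C2)cc2nc(NCc3cc(Cl)ccn3)oc12` gives 190 nM in this assay, and compound 2 `COc1cc(C(=O)N2CC(C)OCC2C2CC(O)C2)cc2nc(N[C@H](C)c3cccc(Cl)c3)oc12` gives 2 nM. Within the data shown here, the one measured step, a 6.6-fold lower number from compound 1 to compound 3 (0.82 log units; beyond the scatter), concerns the whole amide-bound ring and not the group studied here. Compound 4 `COc1cc(C(=O)N2CC(C)OCC2C2CC(O)C2)cc2nc(NCc3cc(Cl)ccn3)oc12` differs from compound 3 by 3-hydroxycyclobutyl in place of 2-hydroxyethyl on a saturated ring carbon. Compound 2 carries the same 3-hydroxycyclobutyl group, but it also differs from compound 3 elsewhere, so its low value cannot be credited to that group alone. Among the measured compounds shown here, no measured step isolates this change, and compound 4 is therefore expected to show only a small shift, a 1.5-fold lower number from compound 3 to compound 4 (0.16 log units; within the scatter), with an estimated 20 nM in this assay, between 6 nM and 60 nM.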

Compound 4, half-maximal inhibitory concentration: 8 nM
Compound 4: the middle estimate sits 2.5-fold (0.40 log units) above what was measured; the measured number falls inside the stated range.
By their numbers in this assay, from the lowest: compound 2; then compound 4; then compound 3; then compound 1.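

The swap of 2-hydroxyethyl for 3-hydroxycyclobutyl on this saturated ring carbon gives a 3.6-fold lower number from compound 3 to compound 4 (0.56 log units; beyond the scatter) and shows that the number responds to the group held here. Compound 4 also shares its amide-bound ring with compound 2, so the change on the nitrogen can now be read alone: (4-chloropyridin-2-yl)methyl in place of 1-(3-chlorophenyl)ethyl gives a 4.0-fold higher number from compound 2 to compound 4 (0.60 log units; beyond the scatter) and so accounts for part of the low value of compound 2. Nothing available explains either step.

As far as these compounds go, how an amine, a carboxylic acid or a longer chain such as 3-hydroxypropyl would behave at this ring carbon remains open.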